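Limits Only: Compound 3 and Its Hydroxylated Neighbour

This account rests on a few compounds, and the source may have more. Where it says the series, first, only, none or still open, it means among the compounds named here.

Measured in an ADME assay on KB cells (Homo sapiens) for cytotoxicity, with a stated time of 48 h (on this read-out higher numbers stand for weaker inhibition and lower numbers for stronger inhibition), three compounds gave these limits, not numbers:
- compound 1 (`CC1=CCC[C@](C)(CC/C(C)=C/CC2=C(O)C(=O)C=C(N[C@@H](CO)C(=O)O)C2=O)[C@@H]1C`) gives > 10 ug/mL as a limit
- compound 2 (`CC1=CCC[C@](C)(CC/C(C)=C/CC2=C(O)C(=O)C=C(N[C@H](CO)C(=O)O)C2=O)[C@@H]1C`) gives > 10 ug/mL as a limit
- compound 3 (`CC1=CCC[C@](C)(CC/C(C)=C/CC2=C(O)C(=O)C=C(N[C@H](C(=O)O)C(C)C)C2=O)[C@@H]1C`) gives > 10 ug/mL as a limit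

Compound 3 therefore has no number of its own and shares the limit of > 10 ug/mL in this assay, at which 3 of the 3 values shown sit, with the other two. Compound 4 (`CC1=CCC[C@](C)(CC/C(C)=C/CC2=C(O)C(=O)C=C(N[C@@H](C(=O)O)[C@H](C)O)C2=O)[C@@H]1C`) has not yet been measured. Its difference from compound 3 is 1-carboxy-2-hydroxypropyl in place of 1-carboxy-2-methylpropyl on an amine nitrogen, in words 1-carboxy-2-hydroxypropyl in place of 1-carboxy-2-methylpropyl on an amine nitrogen.

The measured steps closest to this change are a step that the two limits leave unreadable from compound 2 to compound 3 and a step that the two limits leave unreadable from compound 1 to compound 3, both of which swap the side group on the same amine nitrogen. The remaining one, a step that the two limits leave unreadable from compound 1 to compound 2, is a matter of configuration alone, as shown by the fact that compounds 1 and 2 differ only in the configuration as drawn here. None of these steps has a readable size, and none gives a direction in this assay here. No step beyond the scatter is expected, and compound 4 is expected to report the same limit. The estimated step is a step that the limit leaves unreadable from compound 3 to compound 4, with no direction to be read from it. For compound 4 the estimated value is 15 ug/mL, with an expected range from 8 ug/mL to 40 ug/mL here.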

Compound 4, half-maximal inhibitory concentration: > 10 ug/mL
Compound 4: only a limit was reported (the forecaster's own chance of this, stated with the estimate: 90%); the middle value is on the limit's open side.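

In this assay compound 4 gives > 10 ug/mL, which is a limit and not a number. Among the compounds shown here, compound 1, compound 2 and compound 3 are also reported only as limits, and no step from any of them to compound 4 can be read. The compounds shown leave open how strongly each inhibits, and whether changing the side group on the amine nitrogen alters that inhibition at all.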